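The source may report more compounds than this note shows. Statements on the series, on what has been measured and on what is new or still open speak of the compounds shown alone.

Of the compounds shown here, two share one core and have been measured in a functional assay on MCF7 cells (Homo sapiens) for inhibition, read by MTT assay, with a stated time of 72 h; a higher number here means a weaker inhibitor, a lower number a stronger inhibitor. Compound 1 `CN(C(=O)NC(=O)c1ccccc1F)c1nc(C(F)(F)F)c(C(=O)N/N=C/c2ccc(C(F)(F)F)cc2)s1` gives 4.98 ug/mL. Among the measured compounds shown here, compound 2 `CN(C(=O)NC(=O)c1ccccc1F)c1nc(C(F)(F)F)c(C(=O)N/N=C/c2ccccc2C(F)(F)F)s1` gives 12.2 ug/mL, the higher of the two numbers, and the only step between them is a 2.4-fold higher number from compound 1 to compound 2 (0.39 log units; beyond the scatter). That step moves a trifluoromethyl group around the aromatic ring attached to the carbon with a double bond to nitrogen, on the far side of the core.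

Compound 3 `CN(C(=O)NC(=O)c1c(F)cccc1F)c1nc(C(F)(F)F)c(C(=O)N/N=C/c2ccccc2C(F)(F)F)s1` is not yet measured. It differs from compound 2 in one place: fluoro in place of hydrogen on an aromatic carbon. For the measured compounds named here, this change sits on the other end of the molecule, on the ring that carries the carbonyl bound to the amide nitrogen, so the single measured step does not bear on it directly. Going by the values given here, no measured pair shows what adding a second fluoro group to that ring does, so there is no ground to expect a shift beyond the scatter in this assay. The expected step is therefore a 1.0-fold lower number from compound 2 to compound 3 (0.01 log units; within the scatter). Compound 3 is estimated at 12 ug/mL, with a range from 5 ug/mL to 30 ug/mL.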

Compound 3, half-maximal inhibitory concentration: 20.4 ug/mL
Estimate against measurement, compound 3: 1.7-fold (0.23 log units) below; low and high end bracket the measured number.
By their numbers in this assay, from the lowest: compound 1; then compounds 2 and 3 (each within the scatter of the next).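

In this assay, replacing 2-fluorophenyl with 2,6-difluorophenyl gives a 1.7-fold higher number from compound 2 to compound 3 (0.22 log units; within the scatter), so this first look at the ring on the carbonyl end of the molecule shows no shift that can be told apart from ordinary repeat-to-repeat variation. With 2-(trifluoromethyl)phenyl held fixed at the far end, this aromatic carbon therefore accepts a fluoro group in place of hydrogen without a change beyond the scatter, unlike the earlier move of the trifluoromethyl group, which did exceed it. No supporting measurement is available to explain the size of this step.

On these data alone, this reading rests on a single pair, so it remains open whether the same fluoro addition would read alike with the 4-(trifluoromethyl)phenyl group of compound 1 at the far end. As far as these compounds go, it is also open how this aromatic carbon would respond to a group larger than fluoro, such as chloro, methoxy or an amine, since a fluoro atom adds only a single heavy atom and tests little of what the position can hold.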